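Pyridin-4-yl in place of pyridin-3-yl: notes on the series

The source may report more compounds than this note shows. Statements on the series, on what has been measured and on what is new or still open speak of the compounds shown alone.

- compound 1 `CN1C/C(=C\c2ccncc2)C(=O)/C(=C/c2ccccc2F)C1` at 4900 nM
- compound 2 `O=C1/C(=C/c2cccnc2)CNC/C1=C\c1ccccc1F` at 8890 nM

Both values come from a functional assay on QGY-7703 cells (Homo sapiens) for cytotoxicity, read by MTT assay, with a stated time of 24 h (on this read-out lower numbers stand for stronger inhibition and higher numbers for weaker inhibition), and compound 2 stands within the scatter of compound 1. Compound 3 `O=C1/C(=C/c2ccncc2)CNC/C1=C\c1ccccc1F` has pyridin-4-yl in place of pyridin-3-yl on a double-bonded chain carbon bound to a double-bonded ring carbon. Within the data shown here, no measured step isolates this change, so no shift beyond the scatter is expected. Compound 1 also carries pyridin-4-yl and gives 4900 nM as the nearest reference. The expected change is a 1.4-fold lower number from compound 2 to compound 3 (0.14 log units; within the scatter) as an estimate. For compound 3 the estimated value is 6500 nM, with an expected range from 2800 nM to 15000 nM.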

Compound 3, half-maximal inhibitory concentration: 14200 nM
Beside the measured number, compound 3's estimate is 2.2-fold (0.34 log units) below it; measured number inside the range.
By their numbers in this assay, from the lowest: compounds 1, 2 and 3 (each within the scatter of the next, the first and the last beyond it).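

In this assay pyridin-4-yl in place of pyridin-3-yl gives a 1.6-fold higher number from compound 2 to compound 3 (0.20 log units; within the scatter) and so does not separate the two pyridines at this position. Hydrogen in place of methyl on an amine nitrogen in a ring, with pyridin-4-yl kept, gives a 2.9-fold higher number from compound 1 to compound 3 (0.46 log units; beyond the scatter) and is the one step here that clears the scatter. No measurement at hand accounts for either step.

On these data alone, whether ethyl or acetyl on that amine nitrogen would follow the methyl result stays open, as does pyridin-2-yl on the same chain carbon. Also open, as far as these compounds go, is whether the methyl step holds with pyridin-3-yl.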